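Swapping the pyridyl-ethenyl arm for a naphthyl group

A few compounds are considered here, and "the series" means these few. Any claim that something is new, unique, unknown or untested is made for them only; others in the source may bear on it.

Measured compounds:
- compound 1 `CC1=NC(C)=C(C(=O)O)C(c2cccc(Cl)c2)/C1=C(\O)OC/C=C/c1ccccc1`: 20 nM
- compound 2 `CC1=NC(C)=C(C(=O)O)C(c2cccc(Cl)c2)/C1=C(\O)OC/C=C/C1CCCCC1`: 3.7 nM
- compound 3 `CC1=NC(C)=C(C(=O)O)C(c2cccc(Cl)c2)/C1=C(\O)OC/C=C/c1ccncc1`: 320 nM

In a functional assay on thoracic aorta for inhibition of Voltage-gated L-type calcium channel (Rattus norvegicus) (on this read-out higher numbers stand for weaker inhibition and lower numbers for stronger inhibition), compound 3 gives the highest number of the three, lying a 16-fold higher number from compound 1 to compound 3 (1.20 log units; beyond the scatter) and an 86-fold higher number from compound 2 to compound 3 (1.94 log units; beyond the scatter). Compound 4 `CC1=NC(C)=C(C(=O)O)C(c2cccc(Cl)c2)/C1=C(\O)OCc1ccc2ccccc2c1` differs from compound 3 by naphthalen-2-yl in place of 2-(pyridin-4-yl)ethenyl on a saturated chain carbon bound to an oxygen on an unsaturated carbon. The step most comparable is the earlier exchange of phenyl for pyridin-4-yl, a 16-fold higher number from compound 1 to compound 3 (1.20 log units; beyond the scatter), which compound 4 reverses by bringing back a carbon-only aromatic group. For the measured compounds named here, no measured step shows what dropping the ethenyl link and adding a second ring does. Compound 4 is therefore expected to give a clearly lower number, an 11-fold lower number from compound 3 to compound 4 (1.03 log units; beyond the scatter), landing near compound 1. The estimate for compound 4 in this assay is 30 nM, with a range from 6 nM to 150 nM.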

Compound 4, half-maximal inhibitory concentration: 14 nM
Estimate against measurement, compound 4: 2.1-fold (0.33 log units) above; low and high end bracket the measured number.
By their numbers in this assay, from the lowest: compound 2; then compounds 4 and 1 (each within the scatter of the next); then compound 3.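

In this assay, naphthalen-2-yl on the saturated chain carbon serves as well as 2-phenylethenyl (a 1.4-fold lower number from compound 1 to compound 4 (0.15 log units; within the scatter)), so at least with this group the ethenyl link is not required to reach this range. The change also recovers much of the ground lost with 2-(pyridin-4-yl)ethenyl (a 23-fold lower number from compound 3 to compound 4 (1.36 log units; beyond the scatter)), but does not match 2-cyclohexylethenyl (a 3.8-fold higher number from compound 2 to compound 4 (0.58 log units; beyond the scatter)). No evidence at hand explains these differences.

The compounds shown do not separate losing the ethenyl link from adding the second ring. Phenyl or naphthalen-1-yl directly on that chain carbon would test this.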